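This account rests on a few compounds, and the source may have more. Where it says the series, first, only, none or still open, it means among the compounds named here.

For the measured compounds named here, in a functional assay on CEM-DNR-bulk cells (Homo sapiens), read by MTT assay, with a stated time of 72 h (on this read-out lower numbers stand for stronger inhibition and higher numbers for weaker inhibition), compound 2 `COc1ncnc2c1c(-c1cc3ccccc3o1)cn2[C@@H]1O[C@H](CO)[C@@H](O)[C@H]1O` gives 10800 nM, the only actual number so far. Compound 1 `COc1ncnc2c1c(-c1ccccc1)cn2[C@@H]1O[C@H](CO)[C@@H](O)[C@H]1O` reads > 20000 nM, which is a limit, as noted in the limit of > 20000 nM in this assay, at which 1 of the 2 values shown sits. Going by the values given here, the sole measured step, an at least 1.8-fold lower number from compound 1 to compound 2 (0.26 log units; that floor lies within the scatter), puts 1-benzofuran-2-yl in place of phenyl on an aromatic carbon. Compound 3 `C#Cc1cn([C@@H]2O[C@H](CO)[C@@H](O)[C@H]2O)c2ncnc(OC)c12` carries ethynyl in place of 1-benzofuran-2-yl on an aromatic carbon, with ethynyl in place of 1-benzofuran-2-yl. That measured step involves no ethynyl group and offers only a weak guide, so a modest move towards a lower number is expected in this assay, with wide uncertainty. The expected change is a 2.2-fold lower number from compound 2 to compound 3 (0.33 log units; beyond the scatter). For compound 3 the estimated value is 5000 nM, within a range of 800 nM to 20000 nM.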

Compound 3, half-maximal inhibitory concentration: 3490 nM
Compound 3: the middle estimate sits 1.4-fold (0.16 log units) above what was measured; measured number inside the range.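

For the compounds shown here, at this aromatic carbon, ethynyl, a group with no ring, gives the first step beyond the scatter in this assay: a 3.1-fold lower number from compound 2 to compound 3 (0.49 log units; beyond the scatter). Against phenyl the change reads an at least 5.7-fold lower number from compound 1 to compound 3 (0.75 log units; beyond the scatter), and that size is only a floor. Compound 1 carries a limit, not a number: the limit of > 20000 nM in this assay, at which 1 of the 3 values shown sits.

With ethynyl the only group here without a ring, the compounds shown cannot tell whether dropping the ring itself accounts for the lower number. From the compounds shown here alone, how an amine, a carboxylic acid or a longer alkyne chain at this carbon would read remains open.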